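The source may report more compounds than this note shows. Statements on the series, on what has been measured and on what is new or still open speak of the compounds shown alone.

Measured so far in a functional assay on FM3A cells (Mus musculus) for cytotoxicity; a lower number here means that less compound is needed, a higher number that more compound is needed for the effect:
- Compound 1 `c1ccc(C2OOC3CCCC(c4ccccc4)(OO2)O3)cc1`: 50000 nM
- Compound 2 `CCCCCCCC1OOC2CCCC(c3ccccc3)(OO1)O2`: 12000 nM

Compound 2 holds the lower of the two numbers in this assay, at 12000 nM, and so needs less compound for the effect than compound 1. The next compound, compound 3 `c1ccc(C23CCCC(OOC(C4CCCCC4)OO2)O3)cc1`, carries cyclohexyl in place of heptyl on a saturated ring carbon, between two ring oxygen atoms: cyclohexyl in place of heptyl on a saturated ring carbon.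

Within the data shown here, only one measured step bears on this change. It sits at the same ring carbon and puts heptyl in place of phenyl, giving a 4.2-fold lower number from compound 1 to compound 2 (0.62 log units; beyond the scatter), a modest change. Cyclohexyl, like the phenyl of compound 1, is a ring, but it is not the same ring, and no measurement yet covers it. A partial return towards the higher number of compound 1 is therefore expected, smaller than the measured step and perhaps not clear of the usual scatter. The estimated step in this assay is a 1.7-fold higher number from compound 2 to compound 3 (0.22 log units; within the scatter), in the upward direction. Compound 3 is expected at 20000 nM, within an estimated range of 7000 nM to 55000 nM.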

Compound 3, half-maximal effective concentration: 10000 nM
Beside the measured number, compound 3's estimate is 2.0-fold (0.30 log units) above it, within the range that was stated.
By their numbers in this assay, from the lowest: compounds 3 and 2 (each within the scatter of the next); then compound 1.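

In this assay, replacing the open heptyl chain with cyclohexyl at this saturated ring carbon gives a 1.2-fold lower number from compound 2 to compound 3 (0.08 log units; within the scatter), so the two groups cannot be told apart here even though only cyclohexyl brings a six-membered non-aromatic ring of carbon. Having a ring at this position is therefore not enough to bring back the higher number of compound 1: a non-aromatic ring in place of the phenyl gives a 5.0-fold lower number from compound 1 to compound 3 (0.70 log units; beyond the scatter), which leaves compound 1, with its phenyl, apart from the other two compounds. Nothing available explains why the phenyl stands apart from heptyl and cyclohexyl at this position.

The compounds shown leave open how a longer chain, an amine or a carboxylic acid at this ring carbon would read in this assay, and so whether the closeness of heptyl and cyclohexyl extends to other groups. Going by these compounds, all three compounds also keep the same phenyl group on the other ring atom, so it remains open whether the same picture would hold with a different group there.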